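Two weak sulfonyl analogues and an untested trifluoromethoxy variant

A few compounds are considered here, and "the series" means these few. Any claim that something is new, unique, unknown or untested is made for them only; others in the source may bear on it.

The study measured two compounds in a functional assay on PC-3 cells (Homo sapiens) for inhibition; a lower number here means a stronger inhibitor, a higher number a weaker inhibitor. Compound 1 `COc1cc2nc(N3CCN(C(=O)c4cccc5ccccc45)CC3)nc(N)c2cc1OC` gives 59000 nM. Compound 2 `COc1cc2nc(N3CCN(S(=O)(=O)c4ccccc4[N+](=O)[O-])CC3)nc(N)c2cc1OC` gives 35000 nM; the two values lie within the scatter of each other, so neither can be called stronger. The untested compound 3 `COc1cc2nc(N3CCN(S(=O)(=O)c4ccc(OC(F)(F)F)cc4)CC3)nc(N)c2cc1OC` carries 4-(trifluoromethoxy)phenyl in place of 2-nitrophenyl on a sulfonyl sulfur. For the measured compounds named here, no measured pair shows what such a change does, so for this assay the step is expected to be small, in no particular direction, or none beyond the scatter, with a 1.2-fold lower number from compound 2 to compound 3 (0.07 log units; within the scatter) as the expected step. Compound 3 is accordingly estimated at 30000 nM, within a range from 10000 nM to 90000 nM.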

Compound 3, half-maximal inhibitory concentration: 25000 nM
For compound 3 the middle estimate is 1.2-fold (0.08 log units) above the measured one, within the range that was stated.
By their numbers in this assay, from the lowest: compounds 3, 2 and 1 (each within the scatter of the next, the first and the last beyond it).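

In this assay, for the compounds shown here, the first readable step on a sulfonyl sulfur is a 1.4-fold lower number from compound 2 to compound 3 (0.15 log units; within the scatter) and lies within the scatter. Exchanging 2-nitrophenyl for 4-(trifluoromethoxy)phenyl at this place therefore produces no change that can be separated from repeat variation. No measurement is available that bears on this result.

Going by these compounds, whether any group on the sulfonyl sulfur can move the number beyond the scatter stays open. A phenyl ring carrying an amine or a carboxylic acid, or a simple methyl in place of the ring, would test this.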